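Dimethoxyphenyl in Place of Phenyl on a Chalcone Carbonyl

The compounds below may be only part of what the source reports. "The series", "measured", "known", "first", "only" and "open" are said of these compounds alone.

Measured so far:
compound 1, `COc1ccc(C(=O)/C=C/c2cn(-c3ccccc3)nc2-c2ccsc2)cc1OC`: 2800 nM
compound 2, `O=C(/C=C/c1cn(-c2ccccc2)nc1-c1cccnc1)c1ccccc1`: 4100 nM

In a functional assay on MCF7 cells (Homo sapiens) for inhibition, read by sulforhodamine B assay, with a stated time of 72 h (on this read-out higher numbers stand for weaker inhibition and lower numbers for stronger inhibition), compound 2 gives the highest of the two numbers, and its nearest neighbour is compound 1, which lies within the scatter of it. Compound 3, `COc1ccc(C(=O)/C=C/c2cn(-c3ccccc3)nc2-c2cccnc2)cc1OC`, is not yet measured. It differs from compound 2 in one place: 3,4-dimethoxyphenyl in place of phenyl on a carbonyl carbon. For the measured compounds named here, no step between measured compounds covers this change, so the size is uncertain; a small step toward stronger inhibition, or none beyond the scatter, is expected in this assay. Compound 3 is therefore estimated at 3000 nM (range 1200 nM to 7500 nM), a step of a 1.4-fold lower number from compound 2 to compound 3 (0.14 log units; within the scatter) that is expected to stay near the scatter.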

Compound 3, half-maximal inhibitory concentration: 1700 nM
Compound 3: the middle estimate sits 1.8-fold (0.25 log units) above what was measured; the range from low to high includes it.
By their numbers in this assay, from the lowest: compounds 3, 1 and 2 (each within the scatter of the next, the first and the last beyond it).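

In this assay, for the compounds shown here, the change to 3,4-dimethoxyphenyl in place of phenyl on a carbonyl carbon gives a 2.4-fold lower number from compound 2 to compound 3 (0.38 log units; beyond the scatter) and is the first change at this position with a readable size, one that lies beyond the scatter. Pyridin-3-yl in place of thiophen-3-yl on an aromatic carbon gives a 1.6-fold lower number from compound 1 to compound 3 (0.22 log units; within the scatter) and stays within the scatter, so these two rings are not told apart here. Nothing available explains either result.

From the compounds shown here alone, whether one methoxy group alone would give the same step remains open, as does the outcome with an amine on that carbonyl carbon.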